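A few compounds are considered here, and "the series" means these few. Any claim that something is new, unique, unknown or untested is made for them only; others in the source may bear on it.

Working notes on the series.

Compound 1 `CC(C)c1ccc(OC(Cc2ccc(Cl)cc2)C(=O)O)cc1` gives 10 mg/kg in a functional assay on the whole organism for inhibition, with Rattus norvegicus as the target; on this read-out lower numbers stand for an effect already at smaller amounts and higher numbers for an effect only at larger amounts of compound. Compound 2 `CCc1cccc(CC(C)(Oc2ccc(C(C)C)cc2)C(=O)O)c1` gives 0.5 mg/kg in this assay, and compound 3 `CCCCc1cccc(CC(C)(Oc2ccc(C(C)C)cc2)C(=O)O)c1` gives 1 mg/kg. The step of a 2.0-fold higher number from compound 2 to compound 3 (0.30 log units; within the scatter) is ethyl in place of hydrogen on a saturated chain carbon, two bonds along the chain from an aromatic carbon. How the core of compound 1 differs from that of compound 2 is not broken down here. Compound 4 `CCC(Cc1ccc(Cl)cc1)(Oc1ccc(C(C)C)cc1)C(=O)O` is not yet measured; it is made from compound 1 by ethyl in place of hydrogen on a saturated chain carbon bound to a carbonyl carbon, an oxygen on an aromatic ring and a saturated chain carbon. The place is not the same as in compound 2 to compound 3, where the change sits two bonds along the chain from an aromatic carbon, so this is the same kind of change, not the same. For compound 4 a step of a 2.0-fold lower number from compound 1 to compound 4 (0.30 log units; within the scatter) is expected, resting on the step of a 2.0-fold higher number from compound 2 to compound 3 (0.30 log units; within the scatter) and on compound 2 and compound 3 showing lower numbers than compound 1. Compound 4 is estimated at 5 mg/kg in this assay, between 1.5 mg/kg and 15 mg/kg.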

Compound 4, dose for half-maximal effect: > 5 mg/kg
Compound 4 ended at the assay's limit (the forecaster's own chance of this, stated with the estimate: 5%); the middle value lies on the limit itself.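

In this assay compound 4 gives > 5 mg/kg, which is a limit and not a number. Among the compounds shown here, no step from compound 1 to compound 4 can be read. The compounds shown leave open what ethyl in place of hydrogen does at this place.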